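Replacing the ethyl on the carbonyl of compound 1

The source may hold more compounds than are shown below. What is called first, only, known or untested is meant among the compounds shown, and "the series" means these compounds.

Going by the values given here, in a functional assay on A-431 cells (Homo sapiens) for cytotoxicity, read by MTT assay (on this read-out higher numbers stand for weaker inhibition and lower numbers for stronger inhibition), compound 1 `CCC(=O)Nc1cc(Nc2ncc(Cl)c(N3CCc4sccc4C3)n2)c(OC)cc1N(C)CCN(C)C` gives 2190 nM, the only exact number so far. Compound 2 `CCC(=O)Nc1ccc(OC)c(Nc2ncc(Cl)c(N3CCc4sccc4C3)n2)c1` stands at > 200000 nM, which is a limit of the assay and not a number. Among the compounds with values here, the single measured step is an at least 91-fold higher number from compound 1 to compound 2 (1.96 log units; beyond the scatter), and it comes with hydrogen in place of (2-(dimethylamino)ethyl)(methyl)amino on an aromatic carbon. That step concerns a different place from the one now changed, so it bears on the new change only indirectly.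

Compound 3 `COc1cc(N(C)CCN(C)C)c(NC(=O)C=C(C)C)cc1Nc1ncc(Cl)c(N2CCc3sccc3C2)n1` differs from compound 1 by 2-methylprop-1-en-1-yl in place of ethyl on a carbonyl carbon, with 2-methylprop-1-en-1-yl in place of ethyl on a carbonyl carbon. Within the data shown here, no measured step covers this place, so no shift beyond the scatter is expected in this assay. The expected step is a 1.1-fold higher number from compound 1 to compound 3 (0.06 log units; within the scatter). For compound 3 the estimated value is 2500 nM, within an expected range of 800 nM to 8000 nM.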

Compound 3, half-maximal inhibitory concentration: > 50000 nM
Compound 3: only a limit was reported; the forecaster's own chance of this, stated with the estimate: 3%; middle value at least 20-fold (1.30 log units) from the limit.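

On the carbonyl carbon, 2-methylprop-1-en-1-yl in place of ethyl brings an at least 22-fold higher number from compound 1 to compound 3 (1.35 log units; beyond the scatter) in this assay, so the group at this place is not a free choice. The earlier step, an at least 91-fold higher number from compound 1 to compound 2 (1.96 log units; beyond the scatter), came with hydrogen in place of (2-(dimethylamino)ethyl)(methyl)amino on an aromatic carbon; the new step shows that a change on the carbonyl carbon, with that amine kept, can also move the number beyond the scatter. Compound 3 gives a limit of the assay and not a number: the limit of > 50000 nM in this assay, at which 1 of the 3 values shown sits.

Compound 3 brings the double bond and the larger carbon group together, so the compounds shown do not tell which of the two goes with the step. On these data alone, how an ethenyl group or an unbranched butyl chain on the same carbonyl carbon would read remains open.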